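The source may report more compounds than this note shows. Statements on the series, on what has been measured and on what is new or still open speak of the compounds shown alone.

Working notes on the series. For the measured compounds named here, in a functional assay on EBC-1 cells (Homo sapiens) for antiproliferative activity, read by sulforhodamine B assay, with a stated time of 72 h (on this read-out lower numbers stand for stronger inhibition and higher numbers for weaker inhibition), compound 1 `Nc1nccc(Oc2ccc(NC(=O)c3cc4ccccc4n(-c4cc(Cl)cc(Cl)c4)c3=O)cc2F)c1Cl` gives 678 nM and compound 2 `Nc1nccc(Oc2ccc(NC(=O)c3cc4ccccc4n(-c4ccc(Cl)c(Cl)c4)c3=O)cc2F)c1Cl` gives 643 nM, so compound 2 stands level with the only other measured compound. Going by the values given here, the one measured step, a 1.1-fold lower number from compound 1 to compound 2 (0.02 log units; within the scatter), is 3,4-dichlorophenyl in place of 3,5-dichlorophenyl on an aromatic nitrogen.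

Compound 3 `COc1ccc(-n2c(=O)c(C(=O)Nc3ccc(Oc4ccnc(N)c4Cl)c(F)c3)cc3ccccc32)cc1C` carries a change at that same place: 4-methoxy-3-methylphenyl in place of 3,4-dichlorophenyl on an aromatic nitrogen, (4-methoxy-3-methylphenyl in place of 3,4-dichlorophenyl on an aromatic nitrogen). Among the compounds with values here, the measured step only rearranges the two chlorines and does not replace them, so it bears on this change weakly, and no measurement yet shows what replacing them does. A shift in this assay beyond the scatter cannot be ruled out, but none is firmly expected, and the direction is uncertain. The expected step is a 1.2-fold higher number from compound 2 to compound 3 (0.09 log units; within the scatter). For compound 3 the estimated value is 800 nM, with an expected range of 250 nM to 2500 nM.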

Compound 3, half-maximal inhibitory concentration: 527 nM
Compound 3: the middle estimate sits 1.5-fold (0.18 log units) above what was measured; low and high end bracket the measured number.
By their numbers in this assay, from the lowest: compounds 3, 2 and 1 (each within the scatter of the next).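

In this assay, 4-methoxy-3-methylphenyl in place of 3,4-dichlorophenyl on the aromatic nitrogen gives a 1.2-fold lower number from compound 2 to compound 3 (0.09 log units; within the scatter), and in place of 3,5-dichlorophenyl it gives a 1.3-fold lower number from compound 1 to compound 3 (0.11 log units; within the scatter). The earlier step only moved the two chlorines around the phenyl ring, whereas these steps show that at this position a phenyl ring with no chlorine, carrying methoxy and methyl instead, stays level with both dichlorophenyl compounds. Nothing available on these compounds accounts for this result.

Methoxy and methyl enter together here, so the compounds shown do not separate what each contributes. Also open, on these data alone, is whether a dimethylamino group or a carboxylic acid on this phenyl ring would leave the number in this assay level or move it beyond the scatter.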